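Removing one hydroxy from compound 3

The compounds below may be only part of what the source reports. "The series", "measured", "known", "first", "only" and "open" are said of these compounds alone.

In a functional assay on A549 cells (Homo sapiens) for cytotoxicity, read by MTT assay, with a stated time of 72 h (a higher number here means a weaker inhibitor, a lower number a stronger inhibitor), compound 1 `COc1ccc(/C=N/NC(=O)Nc2cc3c(Nc4ccc(F)c(Cl)c4)ncnc3cc2O[C@H]2CCOC2)c(OC)c1OC` gives 25200 nM. Compound 2 `O=C(N/N=C/c1cc(Br)c(O)c(Br)c1)Nc1cc2c(Nc3ccc(F)c(Cl)c3)ncnc2cc1O[C@H]1CCOC1` gives 8910 nM, and compound 3 `O=C(N/N=C/c1ccc(O)cc1O)Nc1cc2c(Nc3ccc(F)c(Cl)c3)ncnc2cc1O[C@H]1CCOC1` gives 9360 nM. Compound 3 therefore belongs to the lower pair of these three numbers. The gap within that pair is small, a 1.1-fold higher number from compound 2 to compound 3 (0.02 log units; within the scatter), while the step to it from the trimethoxy compound is larger, a 2.7-fold lower number from compound 1 to compound 3 (0.43 log units; beyond the scatter).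

Compound 4 `O=C(N/N=C/c1ccc(O)cc1)Nc1cc2c(Nc3ccc(F)c(Cl)c3)ncnc2cc1O[C@H]1CCOC1` has hydrogen in place of hydroxy on an aromatic carbon, so 2,4-dihydroxyphenyl becomes 4-hydroxyphenyl: hydrogen in place of hydroxy on an aromatic carbon. Among the compounds with values here, no measured step makes exactly this change, so the evidence is indirect. Replacing the 2,3,4-trimethoxyphenyl group with a different ring gave a modest change, a 2.8-fold lower number from compound 1 to compound 2 (0.45 log units; beyond the scatter), and exchanging the two hydroxy-bearing rings gave almost none, as the small gap above shows. The loss of one hydroxy is a smaller edit than either exchange, so no shift beyond the scatter is expected.

The expected step is a 1.1-fold higher number from compound 3 to compound 4 (0.03 log units; within the scatter).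

For compound 4, the estimated value is 10000 nM, with an expected range of 5000 nM to 20000 nM.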

Compound 4, half-maximal inhibitory concentration: 1320 nM
Beside the measured number, compound 4's estimate is 7.6-fold (0.88 log units) above it, and the stated range ends above it.
By their numbers in this assay, from the lowest: compound 4; then compounds 2 and 3 (each within the scatter of the next); then compound 1.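

In this assay, within the data shown here, the hydroxy ortho to a large group turns out to be dispensable and even unfavourable, since replacing it with hydrogen gives a 7.1-fold lower number from compound 3 to compound 4 (0.85 log units; beyond the scatter) and shows that this single position matters more than the ring exchanges among the earlier compounds suggested. The 4-hydroxyphenyl ring also stands apart from the two more heavily substituted rings, with a 6.8-fold lower number from compound 2 to compound 4 (0.83 log units; beyond the scatter) and a 19-fold lower number from compound 1 to compound 4 (1.28 log units; beyond the scatter) making compound 4 the strongest of these four. No measurement shown here explains why hydrogen does better than hydroxy at this position.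

Going by these compounds, it remains open whether the remaining 4-hydroxy contributes anything, which a plain phenyl ring would test. It is also unknown how another small group at the vacated position, such as an amine or a fluorine, would compare with hydrogen.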